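The compounds below may be only part of what the source reports. "The series", "measured", "known", "first", "only" and "open" are said of these compounds alone.

Three compounds have been measured in an assay on microsomes from brain for inhibition of Fatty-acid amide hydrolase 1 (Rattus norvegicus), read by fluorescence and HPLC, with a stated time of 60 min; a lower number here means a stronger inhibitor, a higher number a weaker inhibitor:

Compound 1 `CCCCCCCCc1ccc(OCC(=O)Cn2nnc(-c3cccs3)n2)cc1` gives 32 nM.
Compound 2 `CCCCCCCCc1ccc(OCC(=O)Cn2nnc(Cc3ccccc3)n2)cc1` gives 66 nM.
Compound 3 `CCCCCCCCc1ccc(OCC(=O)Cn2nnnc2-c2cccs2)cc1` gives 55 nM.

Compound 3 is built from the same atoms as compound 1, joined differently; the difference between the two cores is not broken down here. The values of compound 3 and compound 1 lie within the scatter of each other, as do those of compound 3 and compound 2.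

Compound 4 `CCCCCCCCc1ccc(OCC(=O)Cn2nnnc2Cc2ccccc2)cc1` has not yet been measured. It is related to compound 3 by benzyl in place of thiophen-2-yl on an aromatic carbon. The same kind of change links compound 1 and compound 2, namely (benzyl in place of thiophen-2-yl on an aromatic carbon), where it gave a 2.1-fold higher number from compound 1 to compound 2 (0.31 log units; beyond the scatter). The surroundings differ: in compound 3 the place is next to the ring atom that bears a large group, whereas in compound 1 it is two ring bonds from that atom.

Given the step from compound 1 to compound 2, compound 4 is expected to show a 2.1-fold higher number from compound 3 to compound 4 (0.32 log units; beyond the scatter), which rests on a 2.1-fold higher number from compound 1 to compound 2 (0.31 log units; beyond the scatter). Compound 4 is therefore estimated at 115 nM, with a range from 55 nM to 240 nM in this assay.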

Compound 4, half-maximal inhibitory concentration: 320 nM
For compound 4 the middle estimate is 2.8-fold (0.44 log units) below the measured one; measured number outside the range, above it.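

In this assay, benzyl in place of thiophen-2-yl again gave a weaker inhibitor, with a 5.8-fold higher number from compound 3 to compound 4 (0.76 log units; beyond the scatter). The direction of the change carried over from the core of compound 1 to the core of compound 3, but its size did not: the same change on two cores in this assay, a 2.1-fold higher number (0.31 log units; beyond the scatter) from compound 1 to compound 2 and a 5.8-fold higher number (0.76 log units; beyond the scatter) from compound 3 to compound 4, 2.8-fold (0.45 log units) apart, beyond the scatter of two such steps. These two pairs show that the size of this step differs between the two cores, but they do not show why it differs or what the change would do on any further core.

The compounds shown leave open whether a phenyl group, a methyl group or a carboxylic acid on that aromatic carbon would show a similar gap between the two cores.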